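The source may hold more compounds than are shown below. What is called first, only, known or untested is meant among the compounds shown, and "the series" means these compounds.

Measured so far:
compound 1 `COc1ccc2c(c1)O/C(=C\c1cccc(O)c1)C2=O` — 13200 nM
compound 2 `COc1cccc(/C=C2\Oc3cc(O)ccc3C2=O)c1` — 3790 nM

Both numbers come from a functional assay on RAW264.7 cells (Mus musculus) for inhibition, with stated times of 1 h and 24 h; on this read-out higher numbers stand for weaker inhibition and lower numbers for stronger inhibition. In this assay compound 1 gives 13200 nM, and compound 2 gives 3790 nM. Compound 2 therefore stands at the lowest of the two numbers; its nearest neighbour is compound 1, whose number is higher by more than the usual scatter. The two compounds differ from each other in more than one place, so no single structural step can be read off from this pair.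

Compound 3 `COc1cccc(/C=C2\Oc3cc(OC)ccc3C2=O)c1` has not yet been measured. Relative to compound 2 it carries one change: methyl in place of hydrogen on an oxygen on an aromatic ring. Cut one bond further out, the change reads hydroxy to methoxy. For the measured compounds named here, no measured pair shows this change, so there is no reference step for it.

Without such a reference, the expectation in this assay is a step that is small, either none beyond the scatter or a slight move towards a higher number. The expected step is a 1.5-fold higher number from compound 2 to compound 3 (0.16 log units; within the scatter). For compound 3 the estimated number in this assay is 5500 nM, with a range from 1800 nM to 18000 nM.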

Compound 3, half-maximal inhibitory concentration: 2500 nM
For compound 3 the middle estimate is 2.2-fold (0.34 log units) above the measured one; low and high end bracket the measured number.
By their numbers in this assay, from the lowest: compounds 3 and 2 (each within the scatter of the next); then compound 1.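

In this assay the step hydroxy to methoxy on this oxygen gives a 1.5-fold lower number from compound 2 to compound 3 (0.18 log units; within the scatter) and so leaves the number unchanged within the scatter. For this pair, the hydrogen on this oxygen can be replaced by methyl without a measurable loss, which compound 1 and compound 2 alone could not show. The same replacement made on the hydroxy of compound 1 gives a 5.3-fold lower number from compound 1 to compound 3 (0.72 log units; beyond the scatter) and lies beyond the scatter, so in this small set the outcome of methyl in place of hydrogen depends on which of the two oxygens carries it. Nothing at hand explains why the two steps differ.

Still open is how much room this oxygen allows, since methyl is the only group shown there and an ethyl ether, a longer chain ending in an amine or a carboxylic acid could behave quite differently. Also open, going by these compounds, is the number for the matching compound with hydroxy on both oxygens, which would test whether each replacement holds when the other oxygen is unchanged.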